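This account rests on a few compounds, and the source may have more. Where it says the series, first, only, none or still open, it means among the compounds named here.

Working notes on the series. Compound 1 `CCOC(=O)c1c(-c2ccc(OC)cc2)oc2ccc(OCCCN3C(=O)C(=O)c4cc(F)ccc43)cc12` and compound 2 `CCOC(=O)c1c(-c2ccc(F)cc2)oc2ccc(OCCCN3C(=O)C(=O)c4cc(F)ccc43)cc12` share one core and differ only by fluoro in place of methoxy on an aromatic carbon. In an ADME assay on Vero cells (Chlorocebus sabaeus) for cytotoxicity, read by MTT assay, with a stated time of 72 h (a higher number here means that more compound is tolerated, a lower number that less compound is tolerated), compound 1 gives 256000 nM. In this assay compound 2 gives 512000 nM. Within the data shown here, that change made the step of a 2.0-fold higher number from compound 1 to compound 2 (0.30 log units; within the scatter), the only single-point comparison among the measured compounds.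

Compound 3 `CCOC(=O)c1c(-c2ccc(OC)cc2)oc2ccc(OCCCCCCN3C(=O)C(=O)c4cc(F)ccc43)cc12` carries a different core; the difference between the two cores is not broken down here. In this assay compound 3 gives 128000 nM, which is the lowest of the three numbers, within the scatter of compound 1 and beyond the scatter relative to compound 2.

Compound 4 `CCOC(=O)c1c(-c2ccc(F)cc2)oc2ccc(OCCCCCCN3C(=O)C(=O)c4cc(F)ccc43)cc12` stands to compound 3 as compound 2 stands to compound 1: the change is fluoro in place of methoxy on an aromatic carbon, the same kind of change, and both place descriptions read the same word for word. For compound 4 the expected step is a 1.9-fold higher number from compound 3 to compound 4 (0.27 log units; within the scatter), matching the earlier one. This rests on compound 3 at 128000 nM and on the step of a 2.0-fold higher number from compound 1 to compound 2 (0.30 log units; within the scatter), which stayed within the scatter. Compound 4 is therefore estimated at 240000 nM, expected to fall between 110000 nM and 520000 nM.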

Compound 4, half-maximal cytotoxic concentration: 512000 nM
The estimate for compound 4 lay 2.1-fold (0.33 log units) below the measured number, and the stated range covers the measured number.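

In this assay, the change from 4-methoxyphenyl to 4-fluorophenyl gives a 4.0-fold higher number from compound 3 to compound 4 (0.60 log units; beyond the scatter), so the number moves in the same direction on both cores. Among these compounds, with only one pair on each core, this does not fix a size for the change, and it does not show that the change would behave the same way on any further core; only the step on the core of compound 3 lies beyond the scatter, while the step on the core of compound 1 does not. Set side by side, the two steps cannot be told apart, so the change carries across these two cores without a detectable difference in size: the same change on two cores in this assay, a 2.0-fold higher number (0.30 log units; within the scatter) from compound 1 to compound 2 and a 4.0-fold higher number (0.60 log units; beyond the scatter) from compound 3 to compound 4, 2.0-fold (0.30 log units) apart, within the scatter of two such steps.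

The compounds shown leave open whether a chloro or trifluoromethyl group in the same place would follow the same course. They also leave open how the numbers would respond to a carboxylic acid in place of the ethyl ester or to an amine on the chain.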